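The compounds below may be only part of what the source reports. "The series", "measured", "known", "first", "only" and "open" are said of these compounds alone.

Compound 1, whose structure is `Cc1cc(NC(=O)CN2CCC(c3cccc[n+]3[O-])CC2)ccc1F`, gives 75% in a functional assay on HEK293 cells for agonist activity at D(4) dopamine receptor (Homo sapiens), read by FLIPR; on this read-out lower numbers stand for smaller maximal responses and higher numbers for larger maximal responses. Two other compounds share the same kind of measurement. Compound 2, with structure `O=C(CN1CCC(c2ccccn2)CC1)Nc1c(Cl)cc(Cl)cc1Cl`, gives 45% in this assay, and compound 3, with structure `O=C(NCN1CCC(c2cccc[n+]2[O-])CC1)c1ccc2ccccc2c1`, gives 67% there. Among these three numbers the one for compound 1 is the highest; the gap to compound 3 lies within the usual scatter, so nothing separates these two, while the gap to compound 2 lies beyond it.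

Compound 4, with structure `O=C(CN1CCC(c2cccc[n+]2[O-])CC1)Nc1cccc(Cl)c1`, has not yet been measured. It differs from compound 1 in one place: 3-chlorophenyl in place of 4-fluoro-3-methylphenyl on an amide-type nitrogen. Among the compounds with values here, no measured pair shows this exact change, so its effect has to be estimated from the spread of the three numbers. A step from compound 1 to compound 4 of about a number 10 percentage points lower from compound 1 to compound 4 (within the scatter) in this assay is expected, a downward change that may still fall within the scatter. For compound 4 the expected value is therefore 65%, with a likely range from 45% to 85%.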

Compound 4, largest response reached (reported as efficacy), in percent of the reference or control that the assay uses: 76%
Compound 4: middle estimate off by 11 percentage points, on the low side; measured number inside the range.
By their numbers in this assay, from the lowest: compound 2; then compounds 3, 1 and 4 (each within the scatter of the next).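

Within the data shown here, putting 3-chlorophenyl in place of 4-fluoro-3-methylphenyl on the amide-type nitrogen gives a number 1 percentage points higher from compound 1 to compound 4 (within the scatter) in this assay, the first direct comparison at this position. The largest response therefore does not separate these two rings, so for this one pair, a single chlorine on the ring serves as well as the fluorine and methyl together. Nothing available explains this match.

This single pair cannot show how far that tolerance extends, and an unsubstituted phenyl, a methoxyphenyl or a pyridyl group on the same nitrogen could behave quite differently. Compound 2 differs from compound 1 in more than one place, so the compounds shown also leave open which of its differences matters for its lower number.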